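This account rests on a few compounds, and the source may have more. Where it says the series, first, only, none or still open, it means among the compounds named here.

Working notes on the series.

Compound 1 `Cc1cc(C)nc(NS(=O)(=O)c2ccc(/N=C/c3c(Cl)c4ccccc4oc3=O)cc2)n1` carries a 4,6-dimethylpyrimidin-2-yl on the sulfonamide nitrogen; in a functional assay on MCF7 cells (Homo sapiens) for cytotoxicity, read by CCK-8 assay, with a stated time of 48 h (on this read-out lower numbers stand for stronger inhibition and higher numbers for weaker inhibition), compound 1 gives 20 nM. Compound 2 `Cc1cc(NS(=O)(=O)c2ccc(/N=C/c3c(Cl)c4ccccc4oc3=O)cc2)no1` differs from it by 5-methyl-1,2-oxazol-3-yl in place of 4,6-dimethylpyrimidin-2-yl on a sulfonamide nitrogen, and in this assay compound 2 gives 12 nM, a step of a 1.7-fold lower number from compound 1 to compound 2 (0.22 log units; within the scatter). Compound 3 `Cc1ccc2oc(=O)c(/C=N/c3ccc(S(=O)(=O)Nc4nc(C)cc(C)n4)cc3)c(Cl)c2c1` keeps the pyrimidinyl sulfonamide and differs from compound 1 in the core by methyl in place of hydrogen on an aromatic carbon; in this assay compound 3 gives 25 nM, a step of a 1.3-fold higher number from compound 1 to compound 3 (0.10 log units; within the scatter). Compound 2 and compound 3 are not linked by a single change; their two values stand a little further apart than the other pairs.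

Compound 4 `Cc1ccc2oc(=O)c(/C=N/c3ccc(S(=O)(=O)Nc4cc(C)on4)cc3)c(Cl)c2c1` is not yet measured. It differs from compound 3 by 5-methyl-1,2-oxazol-3-yl in place of 4,6-dimethylpyrimidin-2-yl on a sulfonamide nitrogen. This is the same change that separates compound 1 from compound 2, made on the core of compound 3, and the place of the change is the same in both pairs. Among the compounds with values here, only one measured instance of this change exists, and it lay within the scatter.

For compound 4 in this assay a step of a 1.7-fold lower number from compound 3 to compound 4 (0.22 log units; within the scatter) is expected, resting on the step of a 1.7-fold lower number from compound 1 to compound 2 (0.22 log units; within the scatter) made by the same change on the core of compound 1. Compound 4 is therefore estimated at 15 nM in this assay, with a likely range from 7 nM to 32 nM.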

Compound 4, half-maximal inhibitory concentration: 16 nM
Estimate against measurement, compound 4: 1.1-fold (0.03 log units) below, within the range that was stated.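

In this assay, 5-methyl-1,2-oxazol-3-yl in place of 4,6-dimethylpyrimidin-2-yl on the sulfonamide nitrogen gives a 1.6-fold lower number from compound 3 to compound 4 (0.19 log units; within the scatter), and the step carries over from the core of compound 1 to the core of compound 3 with no detectable difference: the same change on two cores in this assay, a 1.7-fold lower number (0.22 log units; within the scatter) from compound 1 to compound 2 and a 1.6-fold lower number (0.19 log units; within the scatter) from compound 3 to compound 4, 1.1-fold (0.03 log units) apart, within the scatter of two such steps. Read the other way round the square, methyl in place of hydrogen on an aromatic carbon gives a 1.3-fold higher number from compound 2 to compound 4 (0.12 log units; within the scatter), and this step also holds with either sulfonamide substituent: the same change on two cores in this assay, a 1.3-fold higher number (0.10 log units; within the scatter) from compound 1 to compound 3 and a 1.3-fold higher number (0.12 log units; within the scatter) from compound 2 to compound 4, 1.1-fold (0.03 log units) apart, within the scatter of two such steps. The four compounds therefore show no sign that the two changes interact, but every step here lies within the scatter, so they do not show that either change has a real effect of its own, nor that a larger step would carry over in the same way.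

The compounds shown leave open whether the steps would still combine in this way with another group on the sulfonamide nitrogen, such as thiazol-2-yl or a plain hydrogen. They also leave open what a methoxy group or a fluorine would do in place of the methyl on the aromatic carbon.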